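A few compounds are considered here, and "the series" means these few. Any claim that something is new, unique, unknown or untested is made for them only; others in the source may bear on it.

Compound 3 `CCCCn1c(CN2CCN(C(=O)C3CC3)CC2)nc2ccccc21` stands lowest of the three measured compounds in an assay on isolated protein for inhibition of aldehyde dehydrogenase 1A1 (Homo sapiens), read by spectrophotometry, tested at 10 uM (on this read-out lower numbers stand for less inhibition and higher numbers for more inhibition at the one concentration tested (going by the name of the read-out)), where compound 3 gives 18.2%. Compound 1 `Cc1ccc(Cn2c(CN3CCN(C(=O)C4CC4)CC3)nc3ccccc32)cc1` gives 51.5% and compound 2 `O=C(C1CC1)N1CCN(Cc2nc3ccccc3n2Cc2ccc(C(F)(F)F)cc2)CC1` gives 37%. The steps down to compound 3 were a number 33.3 percentage points lower from compound 1 to compound 3 (beyond the scatter) and a number 18.8 percentage points lower from compound 2 to compound 3 (beyond the scatter), and between the two aryl compounds a number 14.5 percentage points lower from compound 1 to compound 2 (beyond the scatter). Compound 4 `O=C(C1CC1)N1CCN(Cc2nc3ccccc3n2CC2CC2)CC1` differs from compound 3 by cyclopropyl in place of propyl on a saturated chain carbon bound to an aromatic nitrogen. For the measured compounds named here, none of the measured steps exchanges one small saturated group for another; both large drops removed an aryl group in favour of propyl. The author therefore expects a step of a number 1.8 percentage points higher from compound 3 to compound 4 (within the scatter), within the scatter. For compound 4 the author estimates 20%, with a range of 8% to 34%.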

Compound 4, a percentage reported as inhibition, at one concentration (the size of the read-out at that concentration, not a potency): 21.2%
The estimate for compound 4 lay 1.2 percentage points below the measured number; low and high end bracket the measured number.
By their numbers in this assay, from the lowest: compounds 3 and 4 (each within the scatter of the next); then compound 2; then compound 1.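

In this assay, cyclopropyl in place of propyl on a saturated chain carbon bound to an aromatic nitrogen gave a number 3 percentage points higher from compound 3 to compound 4 (within the scatter), so a ring in this small group leaves the number unmoved. Cyclopropyl also read well short of both aryl groups, with a number 15.8 percentage points lower from compound 2 to compound 4 (beyond the scatter) and a number 30.3 percentage points lower from compound 1 to compound 4 (beyond the scatter), so the loss seen with propyl extends to a small group carrying a ring. For the compounds shown here, no evidence explaining these steps is available. On these data alone, whether a longer chain or cyclohexylmethyl at this place would reach the numbers of the aryl compounds remains open. So does how an amine or a carboxylic acid there would read.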